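Amino in Place of Chloro: What Compound 4 May Show

The source may report more compounds than this note shows. Statements on the series, on what has been measured and on what is new or still open speak of the compounds shown alone.

Of the compounds shown here, three have been measured in a functional assay on LS174T cells (Homo sapiens) for inhibition, with a stated time of 4 days, tested at 10 uM; a higher number here means a stronger effect of the compound at the concentration tested, a lower number a weaker effect. Compound 1 `Fc1cccc(F)c1C#Cc1ccc(-n2cccc2)cc1` gives 96.7%. Compound 2 `Fc1cccc(F)c1C#Cc1ccc2nccc(Cl)c2c1` gives 89.7%. Compound 3 `Fc1cccc(F)c1C#Cc1ccc(-n2cccc2)nc1` gives 95.3%.

Compound 2 has the lowest of the three numbers, but its distance to compound 3 and its distance to compound 1 both lie within the scatter of this assay, so nothing separates the three beyond the usual repeat-to-repeat spread. All three sit at the upper end of the inhibition scale at the concentration tested.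

Compound 4 `Nc1ccnc2ccc(C#Cc3c(F)cccc3F)cc12` has not been measured. It differs from compound 2 in one place: amino in place of chloro on an aromatic carbon.

Among the measured compounds shown here, no measured pair in this set shows a change of this kind, so there is no direct guide to the size of the step. Given that compound 2 gives 89.7% and the neighbouring compounds sit in the same high band, the step of a number 0.3 percentage points higher from compound 2 to compound 4 (within the scatter) that this estimate implies is expected to remain within the scatter, with no clear direction. Compound 4 is therefore expected to give about 90% in this assay, with a range from 76% to 98%.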

Compound 4, a percentage reported as inhibition, at one concentration (the size of the read-out at that concentration, not a potency): 93.9%
Compound 4: middle estimate off by 3.9 percentage points, on the low side, and the stated range covers the measured number.
By their numbers in this assay, from the lowest: compounds 2, 4, 3 and 1 (each within the scatter of the next).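

Among the compounds shown here, the exchange of chloro for amino provides the first step in this set between two compounds that differ in one place. In this assay it gives a number 4.2 percentage points higher from compound 2 to compound 4 (within the scatter) at this aromatic carbon, which lies opposite the ring nitrogen, so this position admits the change without a step beyond the scatter. Amino brings a hydrogen-bond donor and a hydrogen-bond acceptor where chloro has neither, yet this single pair shows no separation between the two compounds at the concentration tested, and nothing shown explains that result.

Still open, from the compounds shown here alone, is whether another group on this same carbon, such as a hydroxyl, a methoxy group or a dimethylamino group, would keep the read-out within the scatter of compound 2 and compound 4. Each number also comes from a single concentration, so the compounds leave open whether compound 2 and compound 4 would differ in the strength of their effect at any other concentration, which a read-out of this kind cannot tell.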